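The compounds below may be only part of what the source reports. "The series", "measured", "known", "first", "only" and "open" are said of these compounds alone.

In a functional assay on the whole organism (Cavia porcellus) with Rattus norvegicus as the target (a lower number here means that less compound is needed, a higher number that more compound is needed for the effect), compound 1 `CC1=CS[C@@](O)(c2ccc(-c3ccccc3)cc2)c2noc(=O)n21` gives 378000000 nM and compound 2 `CC1=CS[C@@](O)(c2cccc(C)c2)c2noc(=O)n21` gives 719000000 nM and these two values lie within the usual scatter of each other. Compound 3 `CC1=CS[C@@](O)(c2cccc([N+](=O)[O-])c2)c2noc(=O)n21` keeps the shared core of compound 2 but carries nitro in place of methyl on an aromatic carbon, meta to a large group (nitro in place of methyl on an aromatic carbon). Among the compounds with values here, no measured pair of compounds shows what this swap does, so a step in this assay beyond the scatter is not expected in either direction. For compound 3 the estimated value is 550000000 nM with an expected range from 200000000 nM to 1500000000 nM around it.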

Compound 3, half-maximal effective concentration: 568000000 nM
For compound 3 the middle estimate is 1.0-fold (0.01 log units) below the measured one; the measured number falls inside the stated range.
By their numbers in this assay, from the lowest: compounds 1, 3 and 2 (each within the scatter of the next).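

In this assay, nitro in place of methyl gives a 1.3-fold lower number from compound 2 to compound 3 (0.10 log units; within the scatter) and so stays within the scatter. On this aromatic carbon, meta to a large group, nitro with its 3 heavy atoms and 2 hydrogen-bond acceptors therefore gives a number that cannot be told apart from that of methyl with its single carbon. No evidence at hand accounts for this result.

On these data alone, whether an amine or a carboxylic acid here would move the number beyond the scatter stays open. So does the effect of a longer chain at this place.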